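Lengthening the Acyl Chain of an Amide Series

The source may report more compounds than this note shows. Statements on the series, on what has been measured and on what is new or still open speak of the compounds shown alone.

Of the compounds shown here, three built on a shared core have been tested in an assay for binding affinity to melatonin receptor (Gallus gallus); a lower number here means a stronger inhibitor, a higher number a weaker inhibitor. Compound 1 `CCC(=O)NCc1cccc(OC)c1` gives 22000 nM. Compound 2 `CCC(=O)NCCCCc1cccc(OC)c1` gives 119 nM. Compound 3 `CCCC(=O)NCCCCc1cccc(OC)c1` gives 208 nM. Among these three numbers compound 3 has the second highest; its nearest neighbour is compound 2, at a distance within the scatter, while compound 1 lies far beyond the scatter above it.

Compound 4 `CCCCC(=O)NCCCCc1cccc(OC)c1` arises from compound 3 by the change (methyl in place of hydrogen on a saturated chain carbon, three bonds along the chain from a carbonyl carbon). Among the compounds with values here, the one measured step that resembles it is a 1.7-fold higher number from compound 2 to compound 3 (0.24 log units; within the scatter), the same kind of change placed two bonds along the chain from the carbonyl carbon rather than three, and that step stayed within the scatter. On this single comparison, a step of about the same small size is expected in this assay, if anything towards a higher number, namely a 1.4-fold higher number from compound 3 to compound 4 (0.16 log units; within the scatter). Compound 4 is therefore estimated at 300 nM, with a range from 120 nM to 750 nM.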

Compound 4, inhibition constant: 9670 nM
Compound 4: middle estimate off by 32-fold (1.51 log units), on the low side; the measured number lies above the stated range.
By their numbers in this assay, from the lowest: compounds 2 and 3 (each within the scatter of the next); then compound 4; then compound 1.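

In this assay, one more methyl on a saturated chain carbon, three bonds along the chain from a carbonyl carbon, gives a 46-fold higher number from compound 3 to compound 4 (1.67 log units; beyond the scatter), a step beyond the scatter, whereas the same kind of change two bonds along the chain gave a 1.7-fold higher number from compound 2 to compound 3 (0.24 log units; within the scatter), which stayed within it. Ethyl in place of hydrogen two bonds along the chain gives an 81-fold higher number from compound 2 to compound 4 (1.91 log units; beyond the scatter), so among these three compounds the chain is not lengthened at an even cost: nearly all of the loss comes with the last carbon added. Nothing shown here bears on why this one methyl costs so much.

As far as these compounds go, whether a longer chain, such as pentyl, would push the number higher still or level off stays open. So does how a branched isopropyl group or a cyclopropyl ring would fare in place of the straight chains shown.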